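The source may hold more compounds than are shown below. What is called first, only, known or untested is meant among the compounds shown, and "the series" means these compounds.

Of the compounds shown here, three have so far been measured in a functional assay on ME-180 cells (Homo sapiens) for antiproliferative activity, read by MTT assay; a higher number here means a weaker inhibitor, a lower number a stronger inhibitor. Compound 1 `Cc1nn2c(-c3nc4c(C)c(C)ccc4[nH]3)c(-c3ccccc3)nc2s1` gives 15800 nM. Compound 3 `Cc1ccc(-c2nc3sc(C)nn3c2-c2nc3c(C)c(C)ccc3[nH]2)cc1` differs from compound 1 by methyl in place of hydrogen on an aromatic carbon; compound 3 gives 9700 nM, and the step is a 1.6-fold lower number from compound 1 to compound 3 (0.21 log units; within the scatter). Compound 2 `Cc1ccc2[nH]c(-c3c(-c4ccc(F)cc4)nc4sc(C)nn34)nc2c1` gives 6600 nM in this assay; how its core differs from the core of compound 1 is not broken down here. Compound 4 `Cc1nn2c(-c3nc4cc(C)c(C)cc4[nH]3)c(-c3ccc(F)cc3)nc2s1` has not been measured yet. It differs from compound 2 by methyl in place of hydrogen on an aromatic carbon. This is the same kind of change as from compound 1 to compound 3, but the place differs: there the methyl entered para to a large group, while here it enters on a ring that is part of a fused or bridged system of two rings, ortho to a methyl group, meta to a fused ring and para to a fused ring. Because a 1.6-fold lower number from compound 1 to compound 3 (0.21 log units; within the scatter) stayed within the scatter, a step of about the same modest size is expected here, a 1.2-fold lower number from compound 2 to compound 4 (0.08 log units; within the scatter). Compound 4 is therefore estimated at 5500 nM, most likely between 2500 nM and 12000 nM.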

Compound 4, half-maximal inhibitory concentration: 6100 nM
The estimate for compound 4 lay 1.1-fold (0.04 log units) below the measured number; measured number inside the range.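

In this assay the methyl brings a 1.1-fold lower number from compound 2 to compound 4 (0.03 log units; within the scatter) and leaves the number practically where it was. This does not show that the methyl has any real effect, and with the methyl in a different place on each core, two pairs cannot say what it would do on another core. What they do show is that the change gives a small step on both cores and that the two steps do not differ: the same change on two cores in this assay, a 1.6-fold lower number (0.21 log units; within the scatter) from compound 1 to compound 3 and a 1.1-fold lower number (0.03 log units; within the scatter) from compound 2 to compound 4, 1.5-fold (0.18 log units) apart, within the scatter of two such steps

The compounds shown leave open whether a different group in place of the methyl, such as an amine, a carboxylic acid or a longer chain, would give a step beyond the scatter. They also leave open whether such a group would behave alike on both cores.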